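Swapping an Aryl Ether for a Biaryl in a Permeability Series

This account rests on a few compounds, and the source may have more. Where it says the series, first, only, none or still open, it means among the compounds named here.

Compound 2 `COc1cccc(CNCCCNc2ccnc3cc(Oc4ccc(Cl)cc4)ccc23)c1O` belongs to a small set of three compounds that share one core, each tested in an ADME assay for permeability, using PAMPA, with a stated time of 30 min, at pH 7.4; a lower number here means that the compound crosses the layer more slowly, a higher number that the compound crosses the layer faster. In that test compound 2 gives 317 10^-6 cm/s. Compound 1 `c1ccc(Oc2ccc3c(NCCCNCc4ccco4)ccnc3c2)cc1` gives 317 10^-6 cm/s and compound 3 `COc1cccc(Oc2ccc3c(NCCCNCc4cc(F)ccc4OC)ccnc3c2)c1` gives 317 10^-6 cm/s, so compound 2 stands level with both at the digits shown, and the readings of all three lie within the scatter of one another. Among the compounds with values here, no pair of measured compounds differs in only one place, so no measured step is available to guide the next comparison.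

Compound 4 `COc1cccc(CNCCCNc2ccnc3cc(-c4ccc(C(F)(F)F)cc4)ccc23)c1O` has not yet been tested. It differs from compound 2 in a single place: 4-(trifluoromethyl)phenyl in place of 4-chlorophenoxy on an aromatic carbon. Within the data shown here, the data hold no measured step that shows how such a swap shifts the reading in this assay. What they do show is that three compounds with rather different groups at the edge of the core all return the same reading, and on that basis the expectation is for no movement beyond the scatter. The step from compound 2 to compound 4 is therefore expected to be small, no change at the digits printed from compound 2 to compound 4 (within the scatter). Compound 4 is expected to give about 317 10^-6 cm/s, with a plausible range from 200 10^-6 cm/s to 450 10^-6 cm/s.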

Compound 4, apparent permeability: 237 10^-6 cm/s
Compound 4: the middle estimate sits 1.3-fold (0.13 log units) above what was measured; measured number inside the range.
By their numbers in this assay, from the lowest: compounds 4, 1, 2 and 3 (each within the scatter of the next).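

In this assay, within the data shown here, putting 4-(trifluoromethyl)phenyl in place of 4-chlorophenoxy on this aromatic carbon gives a 1.3-fold lower number from compound 2 to compound 4 (0.13 log units; within the scatter), the first step between two compounds that differ in one place. Compounds 1, 2 and 3 differ from one another in more than one place, so they could not show what a single change at this position does. This pair shows that, in this one case, the oxygen link can go and the chlorine can give way to trifluoromethyl while the reading stays within the scatter, and no measurement shown here offers a reason for that outcome.

The swap changes the link and the group on the ring together, so the compounds shown leave open what each change does alone, which 4-chlorophenyl or 4-(trifluoromethyl)phenoxy at the same place could separate. Going by these compounds, it also remains open whether this position would stay as undemanding with a very different group there, such as a carboxylic acid, a primary amine or a longer alkyl chain.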